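Chain step from compound 3 to compound 4

This account rests on a few compounds, and the source may have more. Where it says the series, first, only, none or still open, it means among the compounds named here.

In a functional assay on HCT-116 cells (Homo sapiens) for antiproliferative activity, read by MTT assay, with a stated time of 48 h (on this read-out lower numbers stand for stronger inhibition and higher numbers for weaker inhibition), compound 1 (`CCCCCC(CCO)n1cnc2c(Cl)ncnc21`) gives > 50000 nM, which is a limit of the assay and not a number. Compound 2 (`CCCCCCC(CCO)n1cnc2c(Cl)ncnc21`) gives 11900 nM. Compound 3 (`C=C(CO)C(CCCCCC)n1cnc2c(Cl)ncnc21`) gives 30200 nM, the higher of the two true numbers in the series, and its nearest neighbour is compound 2, with a 2.5-fold higher number from compound 2 to compound 3 (0.40 log units; beyond the scatter). That step exchanges 2-hydroxyethyl for 1-(hydroxymethyl)ethenyl and leaves the chain unchanged, so it places compound 3 but says little about the change now in question.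

The next compound, compound 4 (`C=C(CO)C(CCCCCCC)n1cnc2c(Cl)ncnc21`), differs from compound 3 by methyl in place of hydrogen on a saturated chain carbon, seven bonds along the chain from an aromatic nitrogen and a double-bonded chain carbon. Among the compounds with values here, the only measured precedent is the same kind of change one bond closer in, with an at least 4.2-fold lower number from compound 1 to compound 2 (0.62 log units; beyond the scatter). That size is a bound rather than a measured gap, and it comes from a single pair carrying 2-hydroxyethyl. A step in the same direction is therefore expected in this assay, towards a lower number, of modest size and with wide uncertainty. The expected change is a 2.5-fold lower number from compound 3 to compound 4 (0.40 log units; beyond the scatter). For compound 4 the estimated value is 12000 nM, with an expected range of 5000 nM to 28000 nM.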

Compound 4, half-maximal inhibitory concentration: 22400 nM
The estimate for compound 4 lay 1.9-fold (0.27 log units) below the measured number, and the stated range covers the measured number.
By their numbers in this assay, from the lowest: compounds 2, 4 and 3 (each within the scatter of the next, the first and the last beyond it). At a limit, above all of these: compound 1.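

In this assay, methyl in place of hydrogen on a saturated chain carbon, seven bonds along the chain from an aromatic nitrogen and a double-bonded chain carbon, gives a 1.3-fold lower number from compound 3 to compound 4 (0.13 log units; within the scatter), so this pair cannot be told apart on this read-out. Until now the chain extension had been seen only with 2-hydroxyethyl, and with 1-(hydroxymethyl)ethenyl in its place the step does not carry over at the same size: the same change on two cores in this assay, an at least 4.2-fold lower number (0.62 log units; beyond the scatter) from compound 1 to compound 2 and a 1.3-fold lower number (0.13 log units; within the scatter) from compound 3 to compound 4, at least 3.1-fold (0.49 log units) apart, beyond the scatter of two such steps

Compound 1 stands at > 50000 nM, which is a limit of the assay and not a number, so the gap between the two steps is known only as a bound.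

From the compounds shown here alone, whether a longer chain on the 1-(hydroxymethyl)ethenyl compounds would produce a step beyond the scatter remains open, as does whether the two chain steps would differ at all if both started from true numbers. Also open, going by these compounds, is what an amine or a carboxylic acid in place of the hydroxy group would do on either of the two chain lengths.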